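The compounds below may be only part of what the source reports. "The series", "measured", "known", "first", "only" and "open" are said of these compounds alone.

Measured in a functional assay on HCT-116 cells (Homo sapiens) for inhibition, read by MTT assay, with a stated time of 48 h; a lower number here means a stronger inhibitor, a higher number a weaker inhibitor:
- compound 1 `COc1ccc(CN(C(=O)C(C)Br)c2cc(OC)c(OC)c(OC)c2)cc1O` gives 140 nM
- compound 2 `C/C=C/C(=O)N(Cc1ccc(OC)c(N)c1)c1cc(OC)c(OC)c(OC)c1` gives 300 nM

Of these two numbers, compound 1 holds the lower one, and the gap to compound 2 at 300 nM lies beyond the usual scatter. The two compounds differ in more than one place, so their values alone say nothing about any single group.

The next compound to be tested is compound 3 `COc1ccc(CN(C(=O)CCl)c2cc(OC)c(OC)c(OC)c2)cc1O`. It differs from compound 1 in one place: chloromethyl in place of 1-bromoethyl on a carbonyl carbon. Chloromethyl stands in place of 1-bromoethyl on a carbonyl carbon, and the rest of the core of compound 1 stays as it is.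

Going by the values given here, no pair of measured compounds differing in just one place is available, so the data offer no direct guide to the size of this change. With nothing to point either way, no step beyond the scatter is expected in this assay, and no firm direction can be given. The estimated change is a 1.2-fold lower number from compound 1 to compound 3 (0.07 log units; within the scatter), a wide expectation given so little evidence. For compound 3 the expected value is 120 nM, with an estimated range of 40 nM to 360 nM.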

Compound 3, half-maximal inhibitory concentration: 250 nM
For compound 3 the middle estimate is 2.1-fold (0.32 log units) below the measured one, and the stated range covers the measured number.
By their numbers in this assay, from the lowest: compounds 1, 3 and 2 (each within the scatter of the next, the first and the last beyond it).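

In this assay, going by these compounds alone, the exchange gives the first reading of a single change on the shared core: chloromethyl in place of 1-bromoethyl on a carbonyl carbon, whose other neighbour is the amide-type nitrogen, gives a 1.8-fold higher number from compound 1 to compound 3 (0.25 log units; within the scatter) and no step that can be told apart from repeat measurements. This position therefore accepts the group of 2 heavy atoms, with chlorine as its halogen, in place of the group of 3 heavy atoms, with bromine as its halogen, and the number stays within the same range. No measurement at hand explains this result.

Within the data shown here, the single step joins two exchanges, one of bromine for chlorine and one of 1-bromoethyl for a group with one carbon fewer, so bromomethyl or 1-chloroethyl on the same carbonyl carbon would be needed to read each exchange alone. Also open, from the compounds shown here alone, is whether a halogen is needed here at all, a question that a plain methyl, or a longer chain such as propyl, on this carbonyl carbon would address.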